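The source may hold more compounds than are shown below. What is called first, only, known or untested is meant among the compounds shown, and "the series" means these compounds.

Measured compounds in an ADME assay on HEK293 cells (Homo sapiens) for cytotoxicity, read by MTT assay, with a stated time of 48 h; on this read-out lower numbers stand for stronger inhibition and higher numbers for weaker inhibition:
compound 1, `CN(C)CCn1c(N)c(-c2nc3ccccc3[nH]2)c2nc(C#N)c(C#N)nc21`, gives 9730 nM
compound 2, `CCN(CC)CCn1c(N)c(-c2nc3ccccc3[nH]2)c2nc(C#N)c(C#N)nc21`, gives 12200 nM
compound 3, `CN(C)CCCn1c(N)c(-c2nc3ccccc3[nH]2)c2nc(C#N)c(C#N)nc21`, gives 8360 nM

All three share the core of compound 1 and differ only in the side chain that carries the tertiary amine. From compound 1 to compound 2 the change is diethylamino in place of dimethylamino on a saturated chain carbon, two bonds along the chain from an aromatic nitrogen, and it made a 1.3-fold higher number from compound 1 to compound 2 (0.10 log units; within the scatter). From compound 1 to compound 3 the change is (dimethylamino)methyl in place of dimethylamino on a saturated chain carbon, two bonds along the chain from an aromatic nitrogen, and it made a 1.2-fold lower number from compound 1 to compound 3 (0.07 log units; within the scatter). Between compound 2 and compound 3 the data show a 1.5-fold lower number from compound 2 to compound 3 (0.16 log units; within the scatter). None of the three compounds can be set apart from the others on these numbers.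

Compound 4, `CCN(CC)CCCn1c(N)c(-c2nc3ccccc3[nH]2)c2nc(C#N)c(C#N)nc21`, has not been measured in this assay. It differs from compound 3 by diethylamino in place of dimethylamino on a saturated chain carbon, three bonds along the chain from an aromatic nitrogen. This is the same kind of change as the one from compound 1 to compound 2, and among the compounds shown it occurs two times; the two places are not the same word for word, since the earlier change sits two bonds along the chain from an aromatic nitrogen and this one sits three bonds along the chain from an aromatic nitrogen.

The step from compound 3 to compound 4 is expected to be a 1.3-fold higher number from compound 3 to compound 4 (0.10 log units; within the scatter). Among the measured compounds shown here, this expectation rests on the only measured step of this kind, which ran from compound 1 to compound 2 as a 1.3-fold higher number from compound 1 to compound 2 (0.10 log units; within the scatter). For compound 4 the expected value in this assay is 10500 nM, with a range from 6000 nM to 18000 nM.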

Compound 4, half-maximal inhibitory concentration: 7870 nM
For compound 4 the middle estimate is 1.3-fold (0.13 log units) above the measured one; low and high end bracket the measured number.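

In this assay, diethylamino in place of dimethylamino, now three bonds along the chain from an aromatic nitrogen, gives a 1.1-fold lower number from compound 3 to compound 4 (0.03 log units; within the scatter), and the two instances of this change can be set side by side: the same change on two cores in this assay, a 1.3-fold higher number (0.10 log units; within the scatter) from compound 1 to compound 2 and a 1.1-fold lower number (0.03 log units; within the scatter) from compound 3 to compound 4, 1.3-fold (0.12 log units) apart, within the scatter of two such steps The other new steps, a 1.6-fold lower number from compound 2 to compound 4 (0.19 log units; within the scatter) and a 1.2-fold lower number from compound 1 to compound 4 (0.09 log units; within the scatter), also lie within the scatter, so all four compounds remain indistinguishable on these numbers. Among the compounds shown here, the change can therefore be carried between the 2-(dimethylamino)ethyl and 3-(dimethylamino)propyl series without a detectable difference in outcome, but this agreement rests on only two pairs, and since neither step can be told from no change, it does not establish a transferable effect of any size or direction.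

The compounds shown leave open whether a ring amine such as piperidine or morpholine, or a chain longer than 3-(diethylamino)propyl, would produce a step beyond the scatter in this assay. They also leave open what would follow from replacing the tertiary amine with a primary amine or a carboxylic acid, or from changing the shared core rather than the side chain.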